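The source may report more compounds than this note shows. Statements on the series, on what has been measured and on what is new or still open speak of the compounds shown alone.

In a functional assay on the whole organism with Scenedesmus acutus as the target, with a stated time of 20 h (on this read-out higher numbers stand for weaker inhibition and lower numbers for stronger inhibition), compound 1 `O=C1C2=C(CCCC2)C(=O)N1c1ccc(Cl)cc1F` gives 240 nM and compound 2 `CC(C)OC(=O)c1cc(N2C(=O)C3=C(CCCC3)C2=O)ccc1Cl` gives 182 nM while compound 3 `CC(C)OC(=O)c1cc(N2C(=O)C3=C(CCCC3)C2=O)c(F)cc1Cl` gives 89.1 nM, the lowest of the three numbers. The next step leads to compound 4 `C#CCOc1cc(N2C(=O)C3=C(CCCC3)C2=O)c(F)cc1Cl`, with propargyloxy in place of isopropoxycarbonyl on an aromatic carbon. For the measured compounds named here, only one measured step touches that carbon, namely a 2.7-fold lower number from compound 1 to compound 3 (0.43 log units; beyond the scatter), and it is modest. The fluoro step a 2.0-fold lower number from compound 2 to compound 3 (0.31 log units; beyond the scatter) is also modest, and compound 4 keeps that fluoro group. Going by the values given here, no measured compound carries propargyloxy, so the direction is uncertain, but a modest step towards a lower number is expected in this assay. The estimate is a 2.2-fold lower number from compound 3 to compound 4 (0.35 log units; beyond the scatter) as an expected change. For compound 4 the expected value is 40 nM (12 nM to 150 nM).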

Compound 4, half-maximal inhibitory concentration: 141 nM
Estimate against measurement, compound 4: 3.5-fold (0.55 log units) below; the range from low to high includes it.
By their numbers in this assay, from the lowest: compounds 3, 4, 2 and 1 (each within the scatter of the next, the first and the last beyond it).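

In this assay, propargyloxy in place of isopropoxycarbonyl on this aromatic carbon gives a 1.6-fold higher number from compound 3 to compound 4 (0.20 log units; within the scatter), so a group without a carbonyl can stand here with no change that the scatter allows one to read. Measured against hydrogen at the same carbon, propargyloxy gives a 1.7-fold lower number from compound 1 to compound 4 (0.23 log units; within the scatter), whereas isopropoxycarbonyl gave a 2.7-fold lower number from compound 1 to compound 3 (0.43 log units; beyond the scatter), which places compound 4 within the scatter of both compounds although they differ from each other beyond it. Nothing available explains these results.

As far as these compounds go, whether an amine, a carboxylic acid or a longer chain on this carbon would shift the number beyond the scatter remains open. So does whether propargyloxy would give a similar value with hydrogen in place of the fluoro group.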